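Replacing the Hydroxymethyl Amide Side Chain with an Acid

The compounds below may be only part of what the source reports. "The series", "measured", "known", "first", "only" and "open" are said of these compounds alone.

Within the data shown here, compound 3 `CCn1c(C(=O)N[C@H](CO)C(C)C)ccc1C(CC)(CC)c1ccc(OCS(=O)(=O)c2ccccc2)c(C)c1` is the only member of this small set that returns a number rather than a limit in a functional assay on MCF7 cells (Homo sapiens) for antiproliferative activity, read by MTT assay, with a stated time of 24 h; on this read-out higher numbers stand for weaker inhibition and lower numbers for stronger inhibition. In this assay compound 3 gives 25500 nM. Compound 1 `CCn1c(C(=O)NCC(=O)OC)ccc1C(CC)(CC)c1ccc(OCS(=O)(=O)c2ccccc2)c(C)c1` reaches only the limit of this assay, > 50000 nM. Compound 2 `CCn1c(C(=O)NCCC(=O)OC)ccc1C(CC)(CC)c1ccc(OCS(=O)(=O)c2ccccc2)c(C)c1` likewise sits at the limit, > 50000 nM. The two measured steps that bear on the present change are therefore only floors: an at least 1.9-fold lower number from compound 1 to compound 3 (0.29 log units; that floor lies within the scatter) and an at least 1.9-fold lower number from compound 2 to compound 3 (0.29 log units; that floor lies within the scatter), both resting on (the limit of > 50000 nM in this assay, at which 2 of the 3 values shown sit). Compound 4 `CCn1c(C(=O)N[C@H](C)C(=O)O)ccc1C(CC)(CC)c1ccc(OCS(=O)(=O)c2ccccc2)c(C)c1` differs from compound 3 in one place: 1-carboxyethyl in place of 1-(hydroxymethyl)-2-methylpropyl on an amide-type nitrogen. Among the measured compounds shown here, the earlier steps show that changing the substituent on the amide-type nitrogen moved the number at least from the limit down to the single value of compound 3, but they give no reading of how much further, or in which direction, a different substituent would go. With no step beyond the scatter to rest on, the account expects compound 4 to stay at the weak end of this assay, a 1.6-fold higher number from compound 3 to compound 4 (0.20 log units; within the scatter). Compound 4 is estimated at 40000 nM, from 15000 nM to 60000 nM, with a real chance that this assay again returns only its limit.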

Compound 4, half-maximal inhibitory concentration: > 50000 nM
Compound 4: no number, only a limit (the forecaster's own chance of this, stated with the estimate: 45%); at least 1.2-fold (0.09 log units) between middle value and limit.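

Putting 1-carboxyethyl in place of 1-(hydroxymethyl)-2-methylpropyl on the amide-type nitrogen gives, in this assay, an at least 1.9-fold higher number from compound 3 to compound 4 (0.29 log units; that floor lies within the scatter). This is the first step shown that starts from compound 3 rather than ending there, and it shows that a side chain with a defined stereocentre on this nitrogen does not by itself return a number, as compound 3 remains the only compound with one. Its size is only a floor, so the change cannot be called a real loss, and the steps to compound 4 from compound 1 and compound 2 cannot be read, leaving the set with almost no measured range: the limit of > 50000 nM in this assay, at which 3 of the 4 values shown sit.

Among these compounds, it remains open whether the number of compound 3 goes with its hydroxymethyl end or with its branched chain, as compound 4 differs from it in both within the one change. A 1-carboxy-2-methylpropyl group, which would keep the branch and carry the carboxylic acid, or a 2-amino-3-methylbutyl group, with an amine in place of the hydroxyl, would bear on that question in this assay.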